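Benzothiazole-imine series: whole-animal dose response, compound 3 to 4

This account rests on a few compounds, and the source may have more. Where it says the series, first, only, none or still open, it means among the compounds named here.

Measured so far:
compound 1, `Nc1nc2ccc(OC(F)(F)C(F)(F)F)cc2s1` — 2.5 mg/kg
compound 2, `Nc1nc2cccc(OC(F)(F)F)c2s1` — > 10 mg/kg
compound 3, `CNS(=O)(=O)CCn1c(=N)sc2cc(OC(F)(F)F)ccc21` — 4 mg/kg

In a functional assay on the whole organism with Rattus norvegicus as the target (a lower number here means that less compound is needed, a higher number that more compound is needed for the effect), compound 1 gives 2.5 mg/kg. Compound 2 returns only a limit of the assay, > 10 mg/kg, and not a number; that limit is noted as the limit of > 10 mg/kg in this assay, at which 1 of the 3 values shown sits. Compound 3 gives 4 mg/kg in this assay, the higher of the two numbers shown, with compound 1 the nearest value, a gap that falls inside the usual scatter of the measurement, so no order between compound 3 and compound 1 is claimed.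

Compound 4, `N=c1sc2cc(OC(F)(F)F)ccc2n1CCN1CCCCC1`, has not been measured. It differs from compound 3 in one place: piperidin-1-yl in place of methylsulfamoyl on a saturated chain carbon, two bonds along the chain from an aromatic nitrogen. Among the compounds with values here, no step between two measured compounds covers a change of this kind, so there is no measured precedent to lean on. The expectation for compound 4 is a step of no change at the digits printed from compound 3 to compound 4 (within the scatter), that is, no change beyond the scatter in this assay. Compound 4 is thus estimated at 4 mg/kg, with a range from 1.5 mg/kg to 12 mg/kg.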

Compound 4, dose for half-maximal effect: 2 mg/kg
Estimate against measurement, compound 4: 2.0-fold (0.30 log units) above; the measured number falls inside the stated range.
By their numbers in this assay, from the lowest: compounds 4, 1 and 3 (each within the scatter of the next). At a limit, above all of these: compound 2.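

In this assay the exchange of methylsulfamoyl for piperidin-1-yl gives a 2.0-fold lower number from compound 3 to compound 4 (0.30 log units; within the scatter), so this saturated chain carbon, two bonds along the chain from an aromatic nitrogen, carries either group without a change beyond the scatter. Compound 3 alone showed one group at this place; the pair now shows that the whole animal response survives the loss of the hydrogen-bond donor and the double bonds outside aromatic rings, and the entry of a six-membered non-aromatic ring. Nothing in the data shown gives a cause for this step.

On these data alone, what a carboxylic acid or a longer chain would do at this place in this assay stays open. The compounds shown also do not separate the contribution of the chain itself from that of the group at its end.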